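The source may report more compounds than this note shows. Statements on the series, on what has been measured and on what is new or still open speak of the compounds shown alone.

Measured so far:
- compound 1 `O=C(O)c1ccc(CNc2cc(Br)cc3[nH]ncc23)cc1` — 49% in an assay for inhibition of Indoleamine 2,3-dioxygenase 1 (Homo sapiens), read by spectrophotometry, with a stated time of 180 min, tested at 10 uM; a lower number here means a weaker effect, a higher number a stronger effect of the compound at the concentration tested
- compound 2 `Brc1cc(NCc2ccccc2)c2cn[nH]c2c1` — 37%

Among the compounds with values here, of the two measured compounds, compound 2 stands lowest in this assay, and the only measured step is the one that led to it: a number 12 percentage points lower from compound 1 to compound 2 (beyond the scatter), a change in which a carboxy group was replaced by hydrogen on the aromatic carbon of the benzyl ring. Compound 3 `Cc1ccc(CNc2cc(Br)cc3[nH]ncc23)cc1` returns a group to that same place: methyl in place of hydrogen on an aromatic carbon, on an aromatic carbon para to a large group. The step from compound 1 to compound 2 is the only one that bears on this change, and it was modest; a methyl is a much smaller group than a carboxy, so a smaller shift, perhaps none beyond the scatter, is expected. The estimated step is a number 6 percentage points higher from compound 2 to compound 3 (within the scatter). For compound 3 the expected value is 43%, with a range from 28% to 58%.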

Compound 3, a percentage reported as inhibition, at one concentration (the size of the read-out at that concentration, not a potency): 20%
The estimate for compound 3 lay 23 percentage points above the measured number; the measured number lies below the stated range.
By their numbers in this assay, from the lowest: compound 3; then compound 2; then compound 1.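

In this assay a methyl on this aromatic carbon, para to a large group, is not a silent addition: it gives a number 17 percentage points lower from compound 2 to compound 3 (beyond the scatter) and so shows that a single carbon at this place can move the number. Set against the carboxy group at the same place, the methyl gives a number 29 percentage points lower from compound 1 to compound 3 (beyond the scatter) and makes the order of the three groups carboxy, then hydrogen, then methyl, so the number does not simply rise or fall with whether any group is present. Nothing in the data shown explains why the methyl lowers the number.

As far as these compounds go, whether an ethyl group would lower the number further, or an amine or a hydroxy group would behave more like the carboxy group, remains open. Also open, from the compounds shown here alone, is whether these groups would keep the same order on another carbon of this ring.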